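A few compounds are considered here, and "the series" means these few. Any claim that something is new, unique, unknown or untested is made for them only; others in the source may bear on it.

Compound 3 `CC1=C(C(=O)CC(C)C)C(c2ccco2)NC(=O)N1` is the strongest inhibitor among the three compounds measured in an assay on membranes from HEK293 cells for displacement of a labelled ligand from adenosine receptor A2b (Homo sapiens), read by scintillation counting, with a stated time of 30 min (a lower number here means a stronger inhibitor, a higher number a weaker inhibitor), where compound 3 gives 240 nM. Compound 1 `CC1=C(C(=O)C2CC2)C(c2ccco2)NC(=O)N1` gives 1060 nM in this assay, and compound 2 `CCCC(=O)C1=C(C)NC(=O)NC1c1ccco1` gives 807 nM in this assay. The three share one core and differ only in the group attached to the carbonyl carbon: the step of a 1.3-fold lower number from compound 1 to compound 2 (0.12 log units; within the scatter), the step of a 4.4-fold lower number from compound 1 to compound 3 (0.65 log units; beyond the scatter) and the step of a 3.4-fold lower number from compound 2 to compound 3 (0.53 log units; beyond the scatter) together show that lengthening and branching the chain on that carbonyl lowers the number, though only by modest amounts.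

Compound 4 `CC1=C(c2ncc(C)o2)C(c2ccco2)NC(=O)N1` changes something else: 5-methyl-1,3-oxazol-2-yl in place of isobutylcarbonyl on a double-bonded ring carbon. The carbonyl itself, which every measured compound carries, is gone, and an aromatic ring takes its place. For the measured compounds named here, none of the measured steps bears on such an exchange; they only compare chains hanging on a carbonyl that compound 4 no longer has. The expectation must therefore be loose. Going by the values given here, since the best chain gave compound 3 its 240 nM and a swap of the whole group has no precedent here, a somewhat higher number is expected, with wide uncertainty. Compound 4 is estimated to give about 800 nM in this assay, within a range from 200 nM to 4000 nM. For compound 4 the expected step is a 3.3-fold higher number from compound 3 to compound 4 (0.52 log units; beyond the scatter).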

Compound 4, inhibition constant: 905 nM
Beside the measured number, compound 4's estimate is 1.1-fold (0.05 log units) below it; the range from low to high includes it.
By their numbers in this assay, from the lowest: compound 3; then compounds 2, 4 and 1 (each within the scatter of the next).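

Even with the carbonyl gone, the compound still binds in this assay: an aromatic ring on this double-bonded ring carbon does as well as two of the carbonyl groups, as seen in the step of a 1.1-fold higher number from compound 2 to compound 4 (0.05 log units; within the scatter) and the step of a 1.2-fold lower number from compound 1 to compound 4 (0.07 log units; within the scatter), both too small to separate the compounds. The isobutylcarbonyl group alone keeps an edge over the new ring, with a 3.8-fold higher number from compound 3 to compound 4 (0.58 log units; beyond the scatter), so at this position the oxazole can stand in for the propylcarbonyl and cyclopropylcarbonyl groups but does not match the best chain shown. Nothing available explains why the 5-methyl-1,3-oxazol-2-yl group matches some carbonyl groups and falls short of another.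

With a single ring at this position, the compounds shown leave open whether the ring itself or its methyl group accounts for the result, a question that the same ring without its methyl, or with an ethyl group there, could address. As far as these compounds go, it also remains open how a phenyl ring, an ethyl ester or a longer chain on the carbonyl would compare here, and whether any of these findings would hold if the furan-2-yl group were replaced.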